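Hydroxyethyl versus hydroxyethoxy on the ring nitrogen of two purine-like cores

The compounds below may be only part of what the source reports. "The series", "measured", "known", "first", "only" and "open" are said of these compounds alone.

Compound 1 `CC(O)n1cnc2c(N)nc(I)nc21` carries a 1-hydroxyethyl group on the aromatic nitrogen of the five-membered ring. In a functional assay on FM3A cells (Homo sapiens) for inhibition, with FM3A (Mus musculus) as the target (a higher number here means a weaker inhibitor, a lower number a stronger inhibitor), compound 1 gives 452000 nM. Compound 2 `Nc1nc(I)nc2c1ncn2OCCO` differs from it in one place, 2-hydroxyethoxy in place of 1-hydroxyethyl on an aromatic nitrogen. In this assay compound 2 reaches only the limit of the assay, > 500000 nM, so the measured change is an at least 1.1-fold higher number from compound 1 to compound 2 (0.04 log units; that floor lies within the scatter), a floor that lies within the scatter of this kind of measurement.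

Compound 3 `CC(O)n1cnc2c(S)nc(F)nc21` shares the 1-hydroxyethyl group with compound 1 but stands on a different core; how the two cores differ is not broken down here. In this assay compound 3 also reaches only the limit of the assay, > 500000 nM. Going by the values given here, two of the three values known so far sit at this limit (the limit of > 500000 nM in this assay, at which 2 of the 3 values shown sit).

Compound 4 `OCCOn1cnc2c(S)nc(F)nc21` is compound 3 with the same change as before, 2-hydroxyethoxy in place of 1-hydroxyethyl on an aromatic nitrogen. The place of the change is the same word for word in both pairs. Because compound 3 already sits at the limit > 500000 nM and because the same change from compound 1 to compound 2 gave an at least 1.1-fold higher number from compound 1 to compound 2 (0.04 log units; that floor lies within the scatter), compound 4 is expected to stay at or beyond the limit; the expected step is a step that the limit leaves unreadable from compound 3 to compound 4. For compound 4 in this assay the estimate is 800000 nM, with a range from 400000 nM to 2000000 nM.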

Compound 4, half-maximal inhibitory concentration: 155000 nM
For compound 4 the middle estimate is 5.2-fold (0.71 log units) above the measured one; the whole stated range lies above it.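

On the core of compound 3, 2-hydroxyethoxy in place of 1-hydroxyethyl on the aromatic nitrogen gives a stronger inhibitor in this assay, with an at least 3.2-fold lower number from compound 3 to compound 4 (0.50 log units; beyond the scatter). The same change on the core of compound 1 gives an at least 1.1-fold higher number from compound 1 to compound 2 (0.04 log units; that floor lies within the scatter), so in this pair of pairs the outcome of the change does not carry over unchanged from one core to the other: the same change on two cores in this assay, an at least 1.1-fold higher number (0.04 log units; that floor lies within the scatter) from compound 1 to compound 2 and an at least 3.2-fold lower number (0.50 log units; beyond the scatter) from compound 3 to compound 4, at least 3.5-fold (0.55 log units) apart, beyond the scatter of two such steps Neither step has a known size, only a floor, and two pairs set no rule for other cores or show which difference between the cores goes with the different outcome: the limit of > 500000 nM in this assay, at which 2 of the 4 values shown sit.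

Left open is whether a single difference between the two cores accounts for the gap, which a compound joining one core substituent of compound 1 to the other core substituent of compound 3 could begin to separate. Also open, as far as these compounds go, is how this series in this assay responds to a longer chain on the same ring nitrogen, such as 3-hydroxypropoxy, or to a carboxylic acid in place of the terminal hydroxyl of the 2-hydroxyethoxy chain.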